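Swapping Fluoro for Chloro on the Aryl Piperazine Amide

The source may hold more compounds than are shown below. What is called first, only, known or untested is meant among the compounds shown, and "the series" means these compounds.

Measured so far:
- compound 1, `COc1cccc(N2CCN(C(=O)C(C)N3C(=O)CCC3=O)CC2)c1`: 0%
- compound 2, `CC(C(=O)N1CCN(c2ccc(Cl)cc2)CC1)N1C(=O)CCC1=O`: 0%
- compound 3, `CC(C(=O)N1CCN(c2cccc(F)c2)CC1)N1C(=O)CCC1=O`: 100%

In a functional assay on the whole organism (strain Swiss) with Mus musculus as the target, in the maximal electroshock model, with a stated time of 2 h, at a dose of 300 mg/kg by the intraperitoneal route (on this read-out higher numbers stand for a stronger effect at the one dose given and lower numbers for a weaker effect), compound 3 gives the highest of the three numbers, and its two neighbours lie far below it. The step of a number 100 percentage points higher from compound 1 to compound 3 (beyond the scatter) and the step of a number 100 percentage points higher from compound 2 to compound 3 (beyond the scatter) are both large and beyond the scatter, so a fluoro group on the aryl ring of the shared core goes with a strong effect, while methoxy or a 4-chlorophenyl arrangement goes with none.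

Compound 4, `CC(C(=O)N1CCN(c2cccc(Cl)c2)CC1)N1C(=O)CCC1=O`, is not yet measured. It differs from compound 3 by chloro in place of fluoro on an aromatic carbon. Among the compounds with values here, no measured step exchanges chloro for fluoro at the same position, so the closest guides are indirect: compound 2 carries chloro and gives 0%, but as 4-chlorophenyl rather than 3-chlorophenyl. The expected outcome is therefore uncertain, with a real chance of a drop from compound 3, shown as a number 40 percentage points lower from compound 3 to compound 4 (beyond the scatter), and compound 4 is estimated at 60%, between 0% and 100%.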

Compound 4, a percentage reported as activity, at one dose (the size of the read-out at that dose, not a potency): 50%
The estimate for compound 4 lay 10 percentage points above the measured number, within the range that was stated.
By their numbers in this assay, from the lowest: compounds 1 and 2 (each within the scatter of the next); then compound 4; then compound 3.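

In this assay the identity of the halogen on this aromatic carbon counts, since chloro in place of fluoro goes with a number 50 percentage points lower from compound 3 to compound 4 (beyond the scatter) and keeps only part of the effect. Within the data shown here, its place on the ring counts too: 3-chlorophenyl in place of 4-chlorophenyl goes with a number 50 percentage points higher from compound 2 to compound 4 (beyond the scatter) and gives the first view of one group at two ring positions. Fluoro is also not the only group that outdoes methoxy here, as chloro in place of methoxy goes with a number 50 percentage points higher from compound 1 to compound 4 (beyond the scatter) and still leaves a clear effect.

As far as these compounds go, whether bromo or a methyl group on this carbon would keep the effect, and how 4-fluorophenyl would compare with 3-fluorophenyl, stays open. Nothing at hand says why such small exchanges move the read-out so far.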